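The source may report more compounds than this note shows. Statements on the series, on what has been measured and on what is new or still open speak of the compounds shown alone.

Measured so far:
compound 1, `CCOC(=O)c1c(C)[nH]c(=O)c(C#N)c1-c1ccccc1Cl`, 25000 nM
compound 2, `CCOC(=O)c1c(C)[nH]c(=O)c(C#N)c1-c1ccco1`, > 100000 nM

Compound 1 in a functional assay on A549 cells (Homo sapiens) for inhibition, read by MTT assay, with a stated time of 24 h (a higher number here means a weaker inhibitor, a lower number a stronger inhibitor), gives 25000 nM. Compound 2 reaches only the limit of this assay, > 100000 nM, so no number is known for it; this is the limit of > 100000 nM in this assay, at which 1 of the 2 values shown sits. Among the measured compounds shown here, the one measured step, an at least 4.0-fold higher number from compound 1 to compound 2 (0.60 log units; beyond the scatter), is a loss of activity beyond the scatter, and because of the limit of > 100000 nM in this assay, at which 1 of the 2 values shown sits, its true size is unknown.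

Compound 3, `CCOC(=O)c1c(C)[nH]c(=O)c(C#N)c1-c1cccs1`, differs from compound 2 by thiophen-2-yl in place of furan-2-yl on an aromatic carbon. No measured step bears on this exchange directly: the only step shown concerns the replacement of the 2-chlorophenyl group, not an exchange between two five-membered aromatic rings. The two values of compound 1 and compound 2 show that the group at this position can move activity beyond the scatter, and that compound 2 sits at the limit.

Compound 3 is therefore expected near the limit as well, with an estimated value of 80000 nM and a range of 25000 nM to 300000 nM. The expected step is an at least 1.2-fold lower number from compound 2 to compound 3 (0.09 log units; that floor lies within the scatter), which is likely to stay within the scatter or to show only a modest gain.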

Compound 3, half-maximal inhibitory concentration: 20100 nM
Estimate against measurement, compound 3: 4.0-fold (0.60 log units) above, outside the stated range (below it).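

Furan-2-yl and thiophen-2-yl match in their counts of heavy atoms, donors and acceptors and differ only in the hetero atom, oxygen against sulfur, yet in this assay this exchange is not neutral: an at least 4.9-fold lower number from compound 2 to compound 3 (0.69 log units; beyond the scatter). A five-membered aromatic ring on this carbon, opposite the ring nitrogen, can therefore hold the level of the 2-chlorophenyl compound, with a 1.2-fold lower number from compound 1 to compound 3 (0.09 log units; within the scatter), so among these three compounds the loss goes with furan-2-yl and not with ring size alone. The value of compound 2 is a limit of the assay, and the true size of the gain from furan-2-yl to thiophen-2-yl stays unknown because of it: the limit of > 100000 nM in this assay, at which 1 of the 3 values shown sits.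

Still open, as far as these compounds go, is whether a five-membered aromatic ring with nitrogen as its hetero atom, such as pyrrol-2-yl, would follow thiophen-2-yl or furan-2-yl here. Also open, from the compounds shown here alone, is whether a carboxylic acid in place of the ethoxycarbonyl group, or a longer chain in place of the methyl group, would move the value away from the level shared by compound 1 and compound 3.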